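The source may report more compounds than this note shows. Statements on the series, on what has been measured and on what is new or still open speak of the compounds shown alone.

The three measured compounds were tested in an assay on cells for inhibition of cytochrome P450 11B2, mitochondrial (Homo sapiens), read by HTRF; a higher number here means a weaker inhibitor, a lower number a stronger inhibitor. Compound 1 `Cc1ccncc1C(=O)N1CC(Oc2cncc(N3C(=O)c4ccc(Cl)cc4C3(C)C)c2)C1` gives 4 nM in this assay. Compound 2 `CCS(=O)(=O)N1CC(Oc2cncc(N3C(=O)c4ccc(Cl)cc4C3(C)C)c2)C1` carries an ethylsulfonyl group where compound 1 carries a (4-methylpyridin-3-yl)carbonyl group. In this assay compound 2 gives 4 nM. Compound 3 `CCS(=O)(=O)N1CC2(CN(c3cncc(N4C(=O)c5ccc(Cl)cc5C4(C)C)c3)C2)C1` is built on a different core and gives 16 nM in this assay. How the core of compound 3 differs from the core of compound 2 is not broken down here; compound 3 shows the highest of the three numbers, with a gap beyond the scatter to both compound 1 and compound 2.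

The step of no change at the digits printed from compound 2 to compound 1 (within the scatter) rests on the change ((4-methylpyridin-3-yl)carbonyl in place of ethylsulfonyl on an amine nitrogen in a ring). Compound 4 `Cc1ccncc1C(=O)N1CC2(C1)CN(c1cncc(N3C(=O)c4ccc(Cl)cc4C3(C)C)c1)C2` has not yet been measured. It stands to compound 3 as compound 1 stands to compound 2: (4-methylpyridin-3-yl)carbonyl in place of ethylsulfonyl on an amine nitrogen in a ring. The two places are not the same word for word: in compound 2 the ring atom bears a large group, while in compound 3 the four-membered ring is joined to another ring at one shared atom, in a system of two rings, and the ring atom bears two fused rings. The change is therefore the same kind of change, not the same.

Because no change at the digits printed from compound 2 to compound 1 (within the scatter) stayed within the scatter, a similarly small outcome is expected here, no change at the digits printed from compound 3 to compound 4 (within the scatter). Compound 4 is thus expected to give about 16 nM in this assay, with a likely range from 6 nM to 40 nM.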

Compound 4, half-maximal inhibitory concentration: 14 nM
Beside the measured number, compound 4's estimate is 1.1-fold (0.06 log units) above it; low and high end bracket the measured number.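

In this assay, putting (4-methylpyridin-3-yl)carbonyl in place of ethylsulfonyl on the amine nitrogen of the four-membered ring, on the core that carries the two-ring system with one shared atom, gives a 1.1-fold lower number from compound 3 to compound 4 (0.06 log units; within the scatter). Set beside the earlier step on the other core, the exchange behaves alike on both: the same change on two cores in this assay, no change at the digits printed (within the scatter) from compound 2 to compound 1 and a 1.1-fold lower number (0.06 log units; within the scatter) from compound 3 to compound 4, 1.1-fold (0.06 log units) apart, within the scatter of two such steps This shows that, for these two pairs, the two groups can stand in for each other on either core without moving the number beyond the scatter, but it does not show that this holds on a third core, for any other pair of groups, or in any other assay, and it gives no reason for the result.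

Going by these compounds, it remains open whether a smaller acyl group such as acetyl, a methylsulfonyl group, a pyridine ring without its methyl group, or a free amine on the same nitrogen would also leave the number where it stands on these cores. Also open, on these data alone, is whether the exchange would still make so little difference if fluorine took the place of the chlorine that all four compounds share.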